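From Ethylsulfanyl to Dimethylcarbamoyl: An Untested Step

The source may hold more compounds than are shown below. What is called first, only, known or untested is meant among the compounds shown, and "the series" means these compounds.

In a functional assay on HeLa cells (Homo sapiens) for antiproliferative activity, read by CCK-8 assay, with a stated time of 72 h (a higher number here means a weaker inhibitor, a lower number a stronger inhibitor), compound 1 (`COc1ccc(-c2cncnc2-c2cc(OC)c(OC)c(OC)c2)cc1F`) gives 500 nM, compound 2 (`COc1ccc(-c2cncnc2-c2cc(OC)c(OC)c(OC)c2)cc1Cl`) gives 320 nM and compound 3 (`CCSc1ccc(-c2cncnc2-c2cc(OC)c(OC)c(OC)c2)cc1`) gives 370 nM. Compound 3 therefore cannot be separated from the other two: the measured steps are a 1.4-fold lower number from compound 1 to compound 3 (0.13 log units; within the scatter) and a 1.2-fold higher number from compound 2 to compound 3 (0.06 log units; within the scatter), and the halogen swap is a 1.6-fold lower number from compound 1 to compound 2 (0.19 log units; within the scatter). Compound 4 (`COc1cc(-c2ncncc2-c2ccc(C(=O)N(C)C)cc2)cc(OC)c1OC`) has dimethylcarbamoyl in place of ethylsulfanyl on an aromatic carbon, para to a large group: dimethylcarbamoyl in place of ethylsulfanyl on an aromatic carbon. Within the data shown here, no measured compound carries this group, so those small steps guide the expectation only weakly. A move towards a higher number in this assay is nevertheless expected, an estimated 4.1-fold higher number from compound 3 to compound 4 (0.61 log units; beyond the scatter). For compound 4 the estimated value is 1500 nM, within an expected range of 400 nM to 6000 nM.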

Compound 4, half-maximal inhibitory concentration: 790 nM
Beside the measured number, compound 4's estimate is 1.9-fold (0.28 log units) above it; measured number inside the range.
By their numbers in this assay, from the lowest: compounds 2, 3, 1 and 4 (each within the scatter of the next, the first and the last beyond it).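

Replacing ethylsulfanyl with dimethylcarbamoyl gives a 2.1-fold higher number from compound 3 to compound 4 (0.33 log units; beyond the scatter) in this assay and is the first step among these compounds to pass beyond the scatter, though only modestly. Among these compounds, this shows that the aromatic carbon para to a large group responds to the group it carries, which the earlier steps could not show. No measurement offered here accounts for the shift. On these data alone, whether the carbonyl, the nitrogen or the two methyl groups matter remains open. So does how an amine, a carboxylic acid or a longer alkylsulfanyl chain would read there.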